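Methyl on the pyridine ring: compound 2 to compound 3

The compounds below may be only part of what the source reports. "The series", "measured", "known", "first", "only" and "open" are said of these compounds alone.

In an assay for inhibition of protein disulfide-isomerase (Homo sapiens), with a stated time of 1 h (on this read-out higher numbers stand for weaker inhibition and lower numbers for stronger inhibition), two compounds have been measured so far.
Compound 1 `COc1ccc(C(Nc2cc(C)ccn2)c2ccc3cccnc3c2O)cc1O` gives 150 nM.
Compound 2 `CCc1ccc(C(Nc2ccccn2)c2ccc3cccnc3c2O)cc1` gives 170 nM.

Compound 2 and compound 1 lie within the usual scatter of each other, so neither can be called the stronger inhibitor. Compound 3 `CCc1ccc(C(Nc2cc(C)ccn2)c2ccc3cccnc3c2O)cc1` is the next step: methyl in place of hydrogen on an aromatic carbon. Going by the values given here, no pair of measured compounds differs by this methyl alone, so its effect is not known. Compound 1 already carries the methylpyridine group, with other changes besides, and lands close to compound 2. The expected step is therefore none beyond the scatter, a 1.1-fold lower number from compound 2 to compound 3 (0.05 log units; within the scatter). Compound 3 is estimated at 150 nM, within 60 nM to 400 nM.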

Compound 3, half-maximal inhibitory concentration: 5390 nM
Compound 3: the middle estimate sits 36-fold (1.56 log units) below what was measured; the measured number lies above the stated range.
By their numbers in this assay, from the lowest: compounds 1 and 2 (each within the scatter of the next); then compound 3.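

Adding one methyl opposite the ring nitrogen gives a 32-fold higher number from compound 2 to compound 3 (1.50 log units; beyond the scatter) in this assay and shows that this carbon is highly sensitive to even so small a group. Compound 1 carries the same 4-methylpyridin-2-yl group, and 4-ethylphenyl in place of its 3-hydroxy-4-methoxyphenyl gives a 36-fold higher number from compound 1 to compound 3 (1.56 log units; beyond the scatter) and so shows that the methyl alone does not set the number.

From the compounds shown here alone, what the methyl does alongside 3-hydroxy-4-methoxyphenyl stays open, as does whether a chlorine or an amine on this carbon would act like methyl. Nothing shown here gives a reason for these large steps.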